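The compounds below may be only part of what the source reports. "The series", "measured", "known", "first", "only" and "open" are said of these compounds alone.

Three amides that share one core have been tested in an ADME assay on LLC-MK2 cells (Macaca mulatta) for cytotoxicity, read by spectrophotometry and crystal violet staining, with a stated time of 4 days; on this read-out lower numbers stand for higher toxicity in this test and higher numbers for lower toxicity in this test. Compound 3 `CC(C)n1ncc2c(C(=O)Nc3cncnc3)cc(-c3cccs3)nc21` gives 20000 nM, and compound 1 `CC(C)n1ncc2c(C(=O)Nc3cccc(C(N)=O)c3)cc(-c3cccs3)nc21` gives 25000 nM. These two cannot be told apart, since the step between them is a 1.3-fold lower number from compound 1 to compound 3 (0.10 log units; within the scatter). Compound 2 `CC(C)n1ncc2c(C(=O)Nc3c(F)cccc3F)cc(-c3cccs3)nc21` reads > 200000 nM, which is a limit of the assay and not a number. Compound 3 therefore stands level with compound 1 and clearly apart from compound 2, the step being an at least 10-fold lower number from compound 2 to compound 3 (1.00 log units; beyond the scatter).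

Compound 4 `CC(C)n1ncc2c(C(=O)Nc3cc(F)ccc3F)cc(-c3cccs3)nc21` has not been measured. It carries 2,5-difluorophenyl in place of pyrimidin-5-yl on an amide-type nitrogen. The closest guide is the step just given, read backwards, as it also exchanges a difluorophenyl group and pyrimidin-5-yl at this place. A second step points the same way: with 2,6-difluorophenyl in place of 3-carbamoylphenyl, the change is an at least 8.0-fold higher number from compound 1 to compound 2 (0.90 log units; beyond the scatter). For the measured compounds named here, still, no tested compound carries the 2,5-difluorophenyl group itself, so only part of that shift is assumed to carry over. A move towards lower toxicity in this assay is expected, of modest size, and the expected step is a 4.0-fold higher number from compound 3 to compound 4 (0.60 log units; beyond the scatter). The estimate for compound 4 is 80000 nM, with an expected range from 25000 nM to 200000 nM.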

Compound 4, half-maximal cytotoxic concentration: 100000 nM
For compound 4 the middle estimate is 1.3-fold (0.10 log units) below the measured one; the measured number falls inside the stated range.
By their numbers in this assay, from the lowest: compounds 3 and 1 (each within the scatter of the next); then compound 4. At a limit, above all of these: compound 2.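

In this assay, 2,5-difluorophenyl on the amide-type nitrogen gives a 5.0-fold higher number from compound 3 to compound 4 (0.70 log units; beyond the scatter) and a 4.0-fold higher number from compound 1 to compound 4 (0.60 log units; beyond the scatter), so compound 4 stands clearly apart from both of the amides with the low numbers. Until now, the only difluorophenyl amide at this place was compound 2, which gave a limit and so could not show how large the shift was; compound 4 gives a measured number and shows that a second fluorine pattern also goes with lower toxicity in this test. Comparing the two difluorophenyl groups yields only an at least 2.0-fold lower number from compound 2 to compound 4 (0.30 log units; that floor lies within the scatter), and since that floor lies within the scatter, the two cannot be ranked from these values: the limit of > 200000 nM in this assay, at which 1 of the 4 values shown sits.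

The compounds shown leave open whether both fluorines are needed, since a plain phenyl and a monofluorophenyl group do not appear among them. They also leave open how a basic amine or a carboxylic acid on the ring would read here, so the link between difluorophenyl and lower toxicity in this test rests on compound 2 and compound 4 alone.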